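The source may hold more compounds than are shown below. What is called first, only, known or untested is meant among the compounds shown, and "the series" means these compounds.

Measured so far in a functional assay on HCT-116 cells (Homo sapiens) for cytotoxicity, read by MTT assay, with a stated time of 72 h; on this read-out higher numbers stand for weaker inhibition and lower numbers for stronger inhibition
compound 1 `O=S(=O)(c1ccc(F)cc1)c1nc2ccccc2nc1N1CCCC1` gives 20600 nM
compound 2 `Cc1ccc(S(=O)(=O)c2nc3ccccc3nc2N2CCc3ccccc3C2)cc1` gives 39000 nM
compound 3 `COc1ccc(S(=O)(=O)c2nc3ccccc3nc2N2CCc3ccccc3C2)cc1` gives 22100 nM

In this assay compound 3, at 22100 nM, lies within the usual scatter of both compound 1 and compound 2, so it holds no distinct place among the three.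

The next compound is compound 4 (`O=S(=O)(c1ccc(F)cc1)c1nc2ccccc2nc1N1CCc2ccccc2C1`). It differs from compound 3 as follows: fluoro in place of methoxy on an aromatic carbon. In words, the 4-methoxyphenyl becomes 4-fluorophenyl, with fluoro in place of methoxy on an aromatic carbon.

Going by the values given here, one measured step bears on this directly, the swap of methyl for methoxy on an aromatic carbon, which gave a 1.8-fold lower number from compound 2 to compound 3 (0.25 log units; within the scatter). Compound 1 also carries the fluoro, and its value of 20600 nM gives no hint of a large shift, although the rest of its structure is different.

No step beyond the scatter is therefore expected, and the estimated change is a 1.1-fold higher number from compound 3 to compound 4 (0.05 log units; within the scatter). For compound 4 the expected value is 25000 nM, with an estimated range from 12000 nM to 50000 nM.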

Compound 4, half-maximal inhibitory concentration: 16600 nM
Beside the measured number, compound 4's estimate is 1.5-fold (0.18 log units) above it; measured number inside the range.
By their numbers in this assay, from the lowest: compounds 4, 1, 3 and 2 (each within the scatter of the next, the first and the last beyond it).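

In this assay, fluoro in place of methoxy on the aromatic carbon gives a 1.3-fold lower number from compound 3 to compound 4 (0.12 log units; within the scatter), so this swap does not separate the two groups, whereas fluoro in place of methyl gives a 2.3-fold lower number from compound 2 to compound 4 (0.37 log units; beyond the scatter), the only step shown that lies beyond the scatter, and a modest one. Methyl, methoxy and fluoro at this position therefore span a narrow range, with only methyl and fluoro set apart. A second place can now be read as well: with the 4-fluorophenyl kept, 1,2,3,4-tetrahydroisoquinolin-2-yl in place of pyrrolidin-1-yl gives a 1.2-fold lower number from compound 1 to compound 4 (0.09 log units; within the scatter), so exchanging these two ring groups leaves the number within the scatter.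

Going by these compounds, whether an amine, a carboxylic acid or a longer chain on this aromatic carbon would shift the number much further remains open. Nothing measured here bears on the cause of the step from methyl to fluoro.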